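Ring contraction at the thiocarbonyl amine of compound 3

The compounds below may be only part of what the source reports. "The series", "measured", "known", "first", "only" and "open" are said of these compounds alone.

The series shares one core and varies only the amine on the thiocarbonyl carbon. In a functional assay on HeLa cells (Homo sapiens) for cytotoxicity, read by MTT assay, with a stated time of 72 h, tested at 3 uM (a higher number here means more inhibition of growth at the concentration tested, a lower number less inhibition of growth), compound 1 `Cc1ccnc(/C(N)=N/NC(=S)N2CCOCC2)c1` gives 44.7%, compound 2 `Cc1ccnc(/C(N)=N/NC(=S)N2CCSCC2)c1` gives 40.4% and compound 3 `Cc1ccnc(/C(N)=N/NC(=S)N2CCCCC2)c1` gives 23.9%. Compound 3 stands lowest of the three: a number 20.8 percentage points lower from compound 1 to compound 3 (beyond the scatter) and a number 16.5 percentage points lower from compound 2 to compound 3 (beyond the scatter), whereas a number 4.3 percentage points lower from compound 1 to compound 2 (within the scatter). Compound 4 `Cc1ccnc(/C(N)=N/NC(=S)N2CCCC2)c1` differs from compound 3 in one place: pyrrolidin-1-yl in place of piperidin-1-yl on a thiocarbonyl carbon. Within the data shown here, none of the measured steps bears directly on this change; all three swap one atom within a six-membered ring at the same place, and none alters the ring size. What they do show is that the two steps beyond the scatter both end at compound 3, with nothing measured lower. Among the measured compounds shown here, with no direct precedent, no step beyond the scatter is expected in this assay for compound 4, a number 0.1 percentage points higher from compound 3 to compound 4 (within the scatter). Compound 4 is therefore estimated at 24%, with a range from 10% to 40%.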

Compound 4, percent growth inhibition at one concentration: 52.1%
Beside the measured number, compound 4's estimate is 28.1 percentage points below it, outside the stated range (above it).
By their numbers in this assay, from the lowest: compound 3; then compounds 2, 1 and 4 (each within the scatter of the next, the first and the last beyond it).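

In this assay, ring size at the thiocarbonyl carbon matters: pyrrolidin-1-yl in place of piperidin-1-yl gives the step (a number 28.2 percentage points higher from compound 3 to compound 4 (beyond the scatter)), so the low number of compound 3 does not extend to the five-membered ring. Compound 4 also carries no ring hetero atom other than nitrogen, so it goes against reading the low number of compound 3 as a simple loss of the ring oxygen or sulfur; it separates from the thiomorpholine compound (a number 11.7 percentage points higher from compound 2 to compound 4 (beyond the scatter)) but not from the morpholine compound (a number 7.4 percentage points higher from compound 1 to compound 4 (within the scatter)). Nothing available explains this change.

Going by these compounds, whether the gain is specific to the five-membered ring stays open; azetidin-1-yl, azepan-1-yl and the open-chain dimethylamino group at the same place would test this. On these data alone, whether this order holds at other concentrations also stays open.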